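A Charged Tail Group Swapped on a Shared Core

The compounds below may be only part of what the source reports. "The series", "measured", "known", "first", "only" and "open" are said of these compounds alone.

Of the compounds shown here, two from this study have been measured in an assay on LX2 cells for inhibition of COL1A1 promoter (Homo sapiens), read by a luciferase reporter, with a stated time of 24 h, tested at 20 uM; a lower number here means a weaker effect, a higher number a stronger effect of the compound at the concentration tested. Compound 1, with the structure `Cc1ccc(-n2cc(C(=O)Nc3cc(F)cc(F)c3)c(=O)c3ccc(N(C)C)nc32)cc1OCCCCCCC[N+]12CCN(CC1)CC2`, gives 5.07% in this assay. Compound 2, with the structure `Cc1cc(OCCCCCCC[n+]2ccccc2)cc(-n2cc(C(=O)Nc3cc(F)cc(F)c3)c(=O)c3ccc(N(C)C)nc32)c1`, gives 7.7% in this assay. Compound 2 shows the higher of the two numbers, but the gap to compound 1 lies within the scatter of repeated measurements, so the two results cannot be told apart; both describe a small effect at the concentration tested.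

Compound 3, with the structure `CC[N+]1(CCCCCCCOc2cc(C)cc(-n3cc(C(=O)Nc4cc(F)cc(F)c4)c(=O)c4ccc(N(C)C)nc43)c2)CCCC1`, has not yet been measured. It differs from compound 2 in one place, as follows: a group of 7 heavy atoms (6 carbon, 1 nitrogen; one five-membered non-aromatic ring with 1 hetero atom) in place of a group of 6 heavy atoms (5 carbon, 1 nitrogen; one six-membered aromatic ring with 1 hetero atom), on a saturated chain carbon, seven bonds along the chain from an oxygen on an aromatic ring. The charged group at the end of the chain is exchanged for another charged group of similar size, while the rest of the molecule, including the shared core and the chain, is unchanged.

Going by the values given here, no measured pair in this set shows what such a change does. Given that compound 1 and compound 2 carry different charged tail groups yet read alike, the expected step in this assay is none beyond the scatter, written as a number 0.7 percentage points lower from compound 2 to compound 3 (within the scatter). Compound 3 is therefore estimated to give 7% in this assay, with a range from -5% to 20%.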

Compound 3, a percentage reported as inhibition, at one concentration (the size of the read-out at that concentration, not a potency): 35.1%
The estimate for compound 3 lay 28.1 percentage points below the measured number; measured number above the stated range.
By their numbers in this assay, from the lowest: compounds 1 and 2 (each within the scatter of the next); then compound 3.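

The charged group at the end of the chain is not a silent position in this assay: placing the group with a five-membered non-aromatic ring where the six-membered aromatic ring stood gives a number 27.4 percentage points higher from compound 2 to compound 3 (beyond the scatter). This step appears even though both groups carry a net charge of +1 and neither has any hydrogen-bond donors or acceptors, so those shared features alone do not fix the read-out at this position, seven bonds along the chain from an oxygen on an aromatic ring. Nothing available here indicates which difference between the two groups accounts for the step.

This single exchange changes several things at once, including ring size, aromatic character and the number of heavy atoms, and the compounds shown do not separate these features. A six-membered non-aromatic piperidinium ring, a simple trimethylammonium group or a shorter chain carrying the same five-membered ring would each test a different part of this change, and since the read-out comes from one concentration, it leaves potency open too.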